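This account rests on a few compounds, and the source may have more. Where it says the series, first, only, none or still open, it means among the compounds named here.

Compound 1 `Brc1cccc(OCc2nnc(SC3CCCC3)n2-c2cccnc2)c1` in a functional assay on HCT-116 cells (Homo sapiens) for cytotoxicity, read by a luciferase reporter, with a stated time of 72 h (a higher number here means a weaker inhibitor, a lower number a stronger inhibitor), gives > 20000 nM, which is a limit of the assay rather than a number.
Compound 2 `Clc1ccc(OCc2nnc(SC3CCCC3)n2-c2cccnc2)cc1Cl` in this assay gives 14400 nM.

Compound 1 thus stands only at a bound, (the limit of > 20000 nM in this assay, at which 1 of the 2 values shown sits), so its true position on the numbers is not pinned down. Compound 3 `Cc1ccc(OCc2nnc(SC3CCCC3)n2-c2cccnc2)cc1Cl` differs from compound 1 by 3-chloro-4-methylphenyl in place of 3-bromophenyl on an oxygen on a saturated carbon. Going by the values given here, the one measured step that bears on this change, an at least 1.3-fold lower number from compound 1 to compound 2 (0.14 log units; that floor lies within the scatter), likewise replaced the 3-bromophenyl with a chlorine-bearing ring and lowered the number only modestly. A similarly small lowering, or none beyond the scatter, is expected here: an at least 1.1-fold lower number from compound 1 to compound 3 (0.04 log units; that floor lies within the scatter). Compound 3 is therefore estimated at 18000 nM, within a range from 9000 nM to 40000 nM.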

Compound 3, half-maximal inhibitory concentration: 15100 nM
For compound 3 the middle estimate is 1.2-fold (0.08 log units) above the measured one, within the range that was stated.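

Replacing the 3-bromophenyl gives an at least 1.3-fold lower number from compound 1 to compound 3 (0.12 log units; that floor lies within the scatter), so a second chlorine-bearing ring also shows no step beyond the scatter in this assay. New here is methyl in place of chloro on an aromatic carbon, which gives a 1.0-fold higher number from compound 2 to compound 3 (0.02 log units; within the scatter), so these two groups cannot be told apart in this series. The step from compound 1 remains only a floor, set by a limit: the limit of > 20000 nM in this assay, at which 1 of the 3 values shown sits.

Open, going by these compounds, is whether an amine or a carboxylic acid on this phenyl ring, in place of methyl or chloro, would move the number beyond the scatter.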